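The source may report more compounds than this note shows. Statements on the series, on what has been measured and on what is new or still open speak of the compounds shown alone.

The measured compounds are compound 1 `CC1=C(C(=O)OCC2CC2)C(c2ccco2)NC(=O)N1` with 29%, compound 2 `CC1=C(C(=O)OCC2CCC2)C(c2ccco2)NC(=O)N1` with 42%, and compound 3 `CC1=C(C(=O)OCC2CC2)C(c2ccsc2)NC(=O)N1` with 39%, all in an assay on membranes from CHO cells for displacement of a labelled ligand from adenosine receptor A1 (Homo sapiens), read by scintillation counting, with a stated time of 60 min, tested at 1 uM; a higher number here means more inhibition at the concentration tested (going by the name of the read-out), a lower number less inhibition.

Compound 2 differs from compound 1 by cyclobutyl in place of cyclopropyl on a saturated chain carbon bound to an oxygen next to a carbonyl group. That change gave a number 13 percentage points higher from compound 1 to compound 2 (beyond the scatter). Compound 3 differs from compound 1 by thiophen-3-yl in place of furan-2-yl on a saturated ring carbon; this change gave a number 10 percentage points higher from compound 1 to compound 3 (within the scatter), so compound 1 and compound 3 cannot be told apart on this assay. Compound 3 and compound 2 likewise lie close together.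

Compound 4 `CC1=C(C(=O)OCC2CCC2)C(c2ccsc2)NC(=O)N1` has not yet been measured in this assay. It differs from compound 3 by cyclobutyl in place of cyclopropyl on a saturated chain carbon bound to an oxygen next to a carbonyl group, the same change that separates compound 2 from compound 1, made on the core of compound 3 rather than on the core of compound 1. The two cores differ by the change described for compound 1 and compound 3.

The expectation for compound 4 rests on a single measured instance of the change, the step from compound 1 to compound 2, which was a number 13 percentage points higher from compound 1 to compound 2 (beyond the scatter). If the change carries over to the core of compound 3, the expected step is a number 13 percentage points higher from compound 3 to compound 4 (beyond the scatter). For the measured compounds named here, because the only precedent is a number 13 percentage points higher from compound 1 to compound 2 (beyond the scatter), and because the step from compound 1 to compound 3 was a number 10 percentage points higher from compound 1 to compound 3 (within the scatter), the expected value for compound 4 in this assay is estimated at 52%, with a range from 40% to 64%.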

Compound 4, a percentage reported as inhibition, at one concentration (the size of the read-out at that concentration, not a potency): 48%
Compound 4: middle estimate off by 4 percentage points, on the high side; the range from low to high includes it.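

On the core of compound 3, cyclobutyl in place of cyclopropyl gave a number 9 percentage points higher from compound 3 to compound 4 (within the scatter) in this assay, and this step can be set directly beside the one on the core of compound 1: the same change on two cores in this assay, a number 13 percentage points higher (beyond the scatter) from compound 1 to compound 2 and a number 9 percentage points higher (within the scatter) from compound 3 to compound 4, 4 percentage points apart, within the scatter of two such steps

Thiophen-3-yl in place of furan-2-yl, carried onto the core of compound 2, gave a number 6 percentage points higher from compound 2 to compound 4 (within the scatter), and it agrees in the same way with its earlier counterpart: the same change on two cores in this assay, a number 10 percentage points higher (within the scatter) from compound 1 to compound 3 and a number 6 percentage points higher (within the scatter) from compound 2 to compound 4, 4 percentage points apart, within the scatter of two such steps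

Each change thus gave steps on its two cores that cannot be told apart, so these four compounds offer no sign that either change depends on the core that carries it; this does not show a firm gain from either change on the second core, where both new steps stay within the scatter, and two pairs read at a single concentration give neither a potency nor a rule for other cores.

The compounds shown leave open whether the same agreement would hold with a cyclopentyl group or a longer chain in place of the cyclobutyl on that saturated chain carbon. They also leave open how a phenyl group in place of the thiophen-3-yl would behave on either core.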